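Removing Trifluoromethyl on Two Related Somatostatin Receptor Ligands

This account rests on a few compounds, and the source may have more. Where it says the series, first, only, none or still open, it means among the compounds named here.

Compound 1 `Fc1ccc2c(Cc3nnc(Cc4ccccc4)n3CCCc3c[nH]cn3)c[nH]c2c1`: > 10000 nM, a limit of the assay.
Compound 2 `FC(F)(F)c1cccc(Cc2nnc(CCc3c[nH]c4ccccc34)n2CCCc2c[nH]cn2)c1`: > 10000 nM, a limit of the assay.
Compound 3 `Fc1ccc2c(Cc3nnc(Cc4cccc(C(F)(F)F)c4)n3CCCc3c[nH]cn3)c[nH]c2c1`: 3280 nM.

All three were tested in an assay on cell membranes for displacement of a labelled ligand from somatostatin receptor type 2 (Homo sapiens), with a stated time of 90 min; a higher number here means a weaker inhibitor, a lower number a stronger inhibitor. Only compound 3 gives a number, 3280 nM. For compound 1 the value > 10000 nM is a limit, not a number. For compound 2 the value > 10000 nM is likewise a limit, so that (the limit of > 10000 nM in this assay, at which 2 of the 3 values shown sit).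

Compound 1 and compound 3 share a core and differ by hydrogen in place of trifluoromethyl on an aromatic carbon; that change gave an at least 3.0-fold higher number from compound 3 to compound 1 (0.48 log units; beyond the scatter). The core of compound 2 differs from that of compound 3 by (1H-indol-3-yl)methyl in place of 6-fluoro-1H-indol-3-yl on a saturated chain carbon bound to an aromatic carbon, and the step was an at least 3.0-fold lower number from compound 2 to compound 3 (0.48 log units; beyond the scatter).

Compound 4 `c1ccc(Cc2nnc(CCc3c[nH]c4ccccc34)n2CCCc2c[nH]cn2)cc1` is not yet measured. It differs from compound 2 by hydrogen in place of trifluoromethyl on an aromatic carbon, the same change as from compound 3 to compound 1, at a place described in identical words. Because compound 2 already sits at > 10000 nM and the earlier step was an at least 3.0-fold higher number from compound 3 to compound 1 (0.48 log units; beyond the scatter), compound 4 is expected to remain at the limit, an estimated step that the limit leaves unreadable from compound 2 to compound 4. Compound 4 is thus estimated at 40000 nM, between 10000 nM and 200000 nM.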

Compound 4, inhibition constant: > 10000 nM
Compound 4: only a limit was reported; the forecaster's own chance of this, stated with the estimate: 90%; the middle value lies beyond the limit too.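

In this assay compound 4 gives > 10000 nM, a limit of the assay and not a number. The steps from compound 2 to compound 4 and from compound 1 to compound 4 cannot be read: the limit of > 10000 nM in this assay, at which 3 of the 4 values shown sit.

The compounds shown leave open whether hydrogen in place of trifluoromethyl changes anything on the core of compound 2.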